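Hydroxy in Place of Methoxy: Compound 3 Awaits Measurement

A few compounds are considered here, and "the series" means these few. Any claim that something is new, unique, unknown or untested is made for them only; others in the source may bear on it.

Of the compounds shown here, two built on a shared core have so far been tested in a functional assay on SK-MEL-2 cells (Homo sapiens) for cytotoxicity, read by sulforhodamine B assay, with a stated time of 48 h, tested at 100 nM; a lower number here means a stronger effect, a higher number a weaker effect of the compound at the concentration tested. Compound 1 `Cc1cc(O)cc(-c2nn(CC#N)cc2-c2ccnc(-c3ccc(Oc4ccccc4)cc3)c2)c1` gives 101% in this assay, while compound 2 `COc1cc(C)cc(-c2nn(CC#N)cc2-c2ccnc(-c3ccc(N(C)C)cc3)c2)c1` gives 50%. Compound 2 therefore holds the lowest of the two numbers, and its nearest neighbour, compound 1, stands higher by a margin beyond the usual scatter. Compound 3 `Cc1cc(O)cc(-c2nn(CC#N)cc2-c2ccnc(-c3ccc(N(C)C)cc3)c2)c1` is the untested member. It differs from compound 2 in a single place: hydrogen in place of methyl on an oxygen on an aromatic ring. For the measured compounds named here, no measured pair differs in just this way, so the size of this step has no direct precedent; compound 1 also carries the hydroxy, but it differs from compound 2 in a second place too, so its value is no guide. The step is expected to be small, at most a modest weakening that may stay within the scatter. Compound 3 is expected to give 60%, between 30% and 95%. The expected step is a number 10 percentage points higher from compound 2 to compound 3 (within the scatter).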

Compound 3, a percentage reported as activity, at one concentration (the size of the read-out at that concentration, not a potency): 112%
Beside the measured number, compound 3's estimate is 52 percentage points below it; measured number above the stated range.
By their numbers in this assay, from the lowest: compound 2; then compound 1; then compound 3.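

In this assay, hydrogen in place of methyl on an oxygen on an aromatic ring proves to be a major change, with a number 62 percentage points higher from compound 2 to compound 3 (beyond the scatter). With the hydroxy held constant, dimethylamino in place of phenoxy on an aromatic carbon gives a much smaller change, a number 11 percentage points higher from compound 1 to compound 3 (beyond the scatter). The methyl on this oxygen therefore carries real weight in the dimethylamino series, which compound 1 and compound 2 could not show, as they differ in two places.

Going by these compounds, it remains open whether a longer chain on this oxygen, as in ethoxy, would keep the effect seen with methoxy, or whether an amine could stand in place of the hydroxy. On these data alone, it is also open whether methoxy would count for as much alongside phenoxy. Nothing available here accounts for the size of this step.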